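Thiourea amides on liver-cell cytotoxicity: from trifluoromethylphenyl to thiophene

The source may report more compounds than this note shows. Statements on the series, on what has been measured and on what is new or still open speak of the compounds shown alone.

Measured so far:
compound 1, `O=C(NC(=S)n1ccc2c(OCCCCCOc3ccc(Cl)cc3)cccc21)c1ccccc1`: 29500 nM
compound 2, `O=C(NC(=S)N1CCc2c(OCCCCCOc3ccc(Cl)cc3)cccc21)c1ccc(C(F)(F)F)cc1`: 32700 nM

The two measured compounds share a core carrying a five-carbon chain to a chlorophenoxy group, and both were tested in an ADME assay on Huh-7 cells (Homo sapiens) for cytotoxicity; on this read-out lower numbers stand for higher toxicity in this test and higher numbers for lower toxicity in this test. Compound 1 gives 29500 nM there. Compound 2 gives 32700 nM in this assay, a number that sits within the usual scatter of the value of compound 1, so the two compounds cannot be told apart on this read-out. Compound 2 thus stands alongside compound 1 rather than above or below it.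

Compound 3, `O=C(NC(=S)N1CCc2c(OCCCCCOc3ccc(Cl)cc3)cccc21)c1cccs1`, has not yet been measured in this assay. It differs from compound 2 in one place: thiophen-2-yl in place of 4-(trifluoromethyl)phenyl on a carbonyl carbon. Going by the values given here, no step between measured compounds touches this position, so there is nothing to compare the change against directly. Since both measured compounds lie close together, compound 3 is expected to stay in the same region, with a step of a 1.1-fold higher number from compound 2 to compound 3 (0.03 log units; within the scatter) that does not go beyond the scatter. For compound 3 the estimate in this assay is 35000 nM, with a range from 15000 nM to 80000 nM.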

Compound 3, half-maximal cytotoxic concentration: 10700 nM
Compound 3: middle estimate off by 3.3-fold (0.51 log units), on the high side, outside the stated range (below it).
By their numbers in this assay, from the lowest: compound 3; then compounds 1 and 2 (each within the scatter of the next).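

In this assay the group on the carbonyl carbon turns out to matter: thiophen-2-yl in place of 4-(trifluoromethyl)phenyl gives a 3.1-fold lower number from compound 2 to compound 3 (0.49 log units; beyond the scatter) and so marks higher toxicity in this test, a modest step but one beyond the scatter. Going by these compounds alone, the earlier compounds offered no step between measured compounds that differ in this one place, so this is the first sign that an exchange at this position alone can move the number. Nothing available explains why this exchange of a six-membered aromatic ring of carbon only for a five-membered aromatic ring with one hetero atom shifts the read-out.

On these data alone, it remains open whether the shift belongs to the thiophene ring itself or to the loss of the 4-(trifluoromethyl)phenyl group, a question that a furan-2-yl, a thiophen-3-yl or a pyridin-2-yl on the same carbonyl carbon could help to settle. Also open, as far as these compounds go, is whether thiophen-2-yl would bring a similar step on the core of compound 1, and whether the five-carbon chain to the chlorophenoxy group has any bearing on the size of this step.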